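The compounds below may be only part of what the source reports. "The series", "measured", "known", "first", "only" and "open" are said of these compounds alone.

Measured in an ADME assay on MT4 cells (Homo sapiens) for cytotoxicity, read by MTT assay, with a stated time of 96 h; on this read-out lower numbers stand for higher toxicity in this test and higher numbers for lower toxicity in this test:
Compound 1 `COc1ccc(-c2nc3cc(C(C)O)ccc3[nH]2)cc1`: >= 100000 nM, a limit of the assay and not a number
Compound 2 `COc1ccc(-c2nc3cc(/C(C)=N/NC(N)=O)ccc3[nH]2)cc1`: "not determined" (no result reported)
Compound 3 `C/C(=N\NC(N)=S)c1ccc2[nH]c(-c3ccc(C(F)(F)F)cc3)nc2c1`: 2000 nM

Among these three entries, compound 3 gives the only actual number, 2000 nM. Its standing in this assay therefore cannot be set against a second number. The one other result is a limit, described by the limit of >= 100000 nM in this assay, at which 1 of the 3 values shown sits.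

Attention now turns to compound 4 `COc1ccc(-c2nc3cc(/C(C)=N/NC(N)=S)ccc3[nH]2)cc1`, which has not yet been measured. It differs from compound 3 by methoxy in place of trifluoromethyl on an aromatic carbon, para to a large group: methoxy in place of trifluoromethyl on an aromatic carbon. Within the data shown here, no measured pair of compounds shows this change, so the expectation is anchored only on compound 3 at 2000 nM and remains loose. A modest move towards higher numbers, meaning lower toxicity in this test, is expected, and the estimated change is a 2.5-fold higher number from compound 3 to compound 4 (0.40 log units; beyond the scatter). For compound 4 the estimated value in this assay is 5000 nM, with an expected range from 1500 nM to 30000 nM.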

Compound 4, half-maximal cytotoxic concentration: 5000 nM
Compound 4: middle estimate and measured number agree at the digits printed; low and high end bracket the measured number.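

In this assay, the change at this position can now be read directly: methoxy in place of trifluoromethyl, on an aromatic carbon para to a large group, gives a 2.5-fold higher number from compound 3 to compound 4 (0.40 log units; beyond the scatter). With methoxy in place on the ring, changing the other side group gives a much larger move, an at least 20-fold lower number from compound 1 to compound 4 (1.30 log units; beyond the scatter). The entry for compound 1 is a limit of the assay and not a number, so this second step has no upper bound: the limit of >= 100000 nM in this assay, at which 1 of the 4 values shown sits.

The entry for compound 2 holds no result, so the step from it to compound 4 cannot be read. Among these compounds, whether an amine or a carboxylic acid at the same aromatic carbon would follow methoxy or trifluoromethyl remains open, as these two groups give only one step at this position.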